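Chloro removal on a pyridinone anilide core and cell toxicity

The source may hold more compounds than are shown below. What is called first, only, known or untested is meant among the compounds shown, and "the series" means these compounds.

In an ADME assay on MT4 cells (Homo sapiens) for cytotoxicity, read by MTT assay, with a stated time of 5 days (on this read-out lower numbers stand for higher toxicity in this test and higher numbers for lower toxicity in this test), compound 1 `Cc1cc(C#N)cc(C)c1Oc1cc(Nc2ccc(C#N)cc2)[nH]c(=O)c1Cl` reaches only the limit of the assay, > 319000 nM, which is not a number. Compound 3 `Cc1cc(C#N)cc(C)c1Oc1cc(Nc2ccc(C#N)cc2)[nH]c(=O)c1` gives 25000 nM in this assay. The change between them is hydrogen in place of chloro on an aromatic carbon, and it made an at least 12-fold lower number from compound 1 to compound 3 (1.10 log units; beyond the scatter). In this assay, compound 2 `Cc1cc(C)cc(Oc2cc(Nc3ccc(C#N)cc3)[nH]c(=O)c2Cl)c1` gives 21000 nM; the difference between the core of compound 2 and the core of compound 1 is not broken down here. Compound 4 `Cc1cc(C)cc(Oc2cc(Nc3ccc(C#N)cc3)[nH]c(=O)c2)c1` has not been measured. It differs from compound 2 by hydrogen in place of chloro on an aromatic carbon. This is the same kind of change as from compound 1 to compound 3, though the surroundings are not identical: in compound 1 the position is ortho to a large group and para to a (4-cyanophenyl)amino group, while in compound 2 it is ortho to a group of 9 heavy atoms and para to a group of 9 heavy atoms. On these data alone, because compound 1 stands at the limit (the limit of > 319000 nM in this assay, at which 1 of the 3 values shown sits), the true size of that step is unknown. For compound 4 a smaller step is expected, a 1.8-fold lower number from compound 2 to compound 4 (0.24 log units; within the scatter), since compound 2 already gives 21000 nM. Compound 4 is estimated at 12000 nM, between 4000 nM and 40000 nM.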

Compound 4, half-maximal cytotoxic concentration: 46000 nM
Compound 4: middle estimate off by 3.8-fold (0.58 log units), on the low side; the whole stated range lies below it.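

Going from chloro to hydrogen on the core of compound 2 gave a 2.2-fold higher number from compound 2 to compound 4 (0.34 log units; beyond the scatter), opposite in direction to the step on the core of compound 1, so in this assay the change does not carry from one of these cores to the other: the same change on two cores in this assay, an at least 12-fold lower number (1.10 log units; beyond the scatter) from compound 1 to compound 3 and a 2.2-fold higher number (0.34 log units; beyond the scatter) from compound 2 to compound 4, at least 27-fold (1.44 log units) apart, beyond the scatter of two such steps. On these data alone, the true size of the earlier step stays unknown, and compound 1 gives a limit of the assay, not a number: the limit of > 319000 nM in this assay, at which 1 of the 4 values shown sits. These two pairs show that the core matters to the outcome of this change, but they do not show why, and they give no rule for any other core in the series.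

The compounds shown leave open how a methyl, a methoxy or an amine at this place on the shared ring would read in this assay. They also leave open which part of the difference between the core of compound 1 and the core of compound 2 sets the two steps apart.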